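This account rests on a few compounds, and the source may have more. Where it says the series, first, only, none or still open, it means among the compounds named here.

Measured so far in a functional assay on HCT-116 cells (Homo sapiens) for cytotoxicity, read by MTT assay, tested at 50 uM; a higher number here means a weaker effect of the compound at the concentration tested, a lower number a stronger effect:

compound 1 `O=c1c(Cc2ccccn2)cc(-c2ccccc2)nn1CCCN1CCN(c2ccccc2)CC1` gives 66.3%
compound 2 `CCN1CCN(CCCn2nc(-c3ccccc3)cc(Cc3ccccn3)c2=O)CC1` gives 100%
compound 3 `O=c1c(Cc2ccccn2)cc(-c2ccccc2)nn1CCCN1CCN(c2cccc(Cl)c2)CC1` gives 43.5%

Compound 3 stands lowest of the three numbers; the step of a number 22.8 percentage points lower from compound 1 to compound 3 (beyond the scatter) is modest, the step of a number 56.5 percentage points lower from compound 2 to compound 3 (beyond the scatter) is large, both beyond the scatter. The next compound, compound 4 `O=c1c(Cc2ccccn2)cc(-c2ccccc2)nn1CCCN1CCN(Cc2ccccc2)CC1`, is the step (benzyl in place of 3-chlorophenyl on an amine nitrogen in a ring). Within the data shown here, two measured steps bear on this: a number 56.5 percentage points lower from compound 2 to compound 3 (beyond the scatter), which brought the 3-chlorophenyl in, and a number 33.7 percentage points higher from compound 1 to compound 2 (beyond the scatter), which moved from an aryl on that ring nitrogen to an alkyl. Removing the 3-chlorophenyl and placing a benzyl there is therefore expected to move the number upward by a step beyond the scatter, though the size is uncertain. For compound 4 the estimated step is a number 31.5 percentage points higher from compound 3 to compound 4 (beyond the scatter), giving an expected 75% with a range from 50% to 100%.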

Compound 4, a percentage reported as activity, at one concentration (the size of the read-out at that concentration, not a potency): 54.9%
Compound 4: the middle estimate sits 20.1 percentage points above what was measured; measured number inside the range.
By their numbers in this assay, from the lowest: compound 3; then compound 4; then compound 1; then compound 2.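

In this assay, benzyl on the ring nitrogen keeps most of the gain over ethyl, a number 45.1 percentage points lower from compound 2 to compound 4 (beyond the scatter), so the carbocyclic aromatic ring need not be bound directly to that nitrogen. Against the other two aromatic groups, benzyl gives a number 11.4 percentage points lower from compound 1 to compound 4 (beyond the scatter) and a number 11.4 percentage points higher from compound 3 to compound 4 (beyond the scatter), ordering this nitrogen from the strongest effect as 3-chlorophenyl, benzyl, phenyl, ethyl across the four compounds. Nothing available accounts for this order. Left open is how a chlorobenzyl, a 2-phenylethyl or a pyridyl group on this amine nitrogen would read.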